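The compounds below may be only part of what the source reports. "The series", "measured", "known", "first", "only" and "open" are said of these compounds alone.

Compound 1 `COc1cc(-c2nn(-c3cccc(NC(=O)c4cccc(C(F)(F)F)c4)c3)cc2-c2ccncc2)ccc1Cl`: > 50000 nM
Compound 2 `O=C(Nc1cccc(-n2cc(-c3ccncc3)c(-c3ccc(Cl)c(O)c3)n2)c1)Nc1cc(C(F)(F)F)cc(C(F)(F)F)c1`: 3030 nM
Compound 3 `O=C(Nc1cccc(-n2cc(-c3ccncc3)c(-c3ccc(Cl)c(O)c3)n2)c1)Nc1ccc(Cl)c(C(F)(F)F)c1`: 1730 nM

In a functional assay on SK-MEL-2 cells (Homo sapiens) for inhibition, read by sulforhodamine B assay, with a stated time of 48 h (a lower number here means a stronger inhibitor of growth, a higher number a weaker inhibitor of growth), compound 1 gives only a limit, > 50000 nM, so its number is not known (the limit of > 50000 nM in this assay, at which 1 of the 3 values shown sits). In this assay, within the data shown here, compound 2 gives 3030 nM and compound 3 gives 1730 nM; the two values lie within the usual scatter of each other, and both compounds carry a carbamoyl linkage like the one in compound 4. Compound 4 `COc1cc(-c2nn(-c3cccc(NC(=O)Nc4ccc(Cl)c(Cl)c4)c3)cc2-c2ccncc2)ccc1Cl` differs from compound 1 by (3,4-dichlorophenyl)amino in place of 3-(trifluoromethyl)phenyl on a carbonyl carbon. Among the measured compounds shown here, no measured step joins compound 1 to compound 4. Because compound 1 sits at the limit (the limit of > 50000 nM in this assay, at which 1 of the 3 values shown sits), the step can only be downward or none. Compound 4 is expected to give about 8000 nM in this assay, between 2500 nM and 50000 nM. The expected step is an at least 6.2-fold lower number from compound 1 to compound 4 (0.79 log units; beyond the scatter), downward.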

Compound 4, concentration for total growth inhibition: 2350 nM
Beside the measured number, compound 4's estimate is 3.4-fold (0.53 log units) above it, and the stated range ends above it.
By their numbers in this assay, from the lowest: compounds 3, 4 and 2 (each within the scatter of the next). At a limit, above all of these: compound 1.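

In this assay, (3,4-dichlorophenyl)amino in place of 3-(trifluoromethyl)phenyl on a carbonyl carbon gives an at least 21-fold lower number from compound 1 to compound 4 (1.32 log units; beyond the scatter). This shows that, on the core of compound 1, this one change is enough to bring a compound off the limit to a readable number. Compound 1 gives only a limit, so the step has a floor but no known size: the limit of > 50000 nM in this assay, at which 1 of the 4 values shown sits.

The compounds shown leave open whether the added amino link or the chlorine atoms account for the step. They also leave open how a plain phenylamino or a cyclohexylamino group would read at this place.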